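Methoxy to trifluoromethoxy in a two-compound series

The source may report more compounds than this note shows. Statements on the series, on what has been measured and on what is new or still open speak of the compounds shown alone.

Measured in a functional assay on CWR22R cells (Homo sapiens) for antiproliferative activity, read by colorimetric assay and sulforhodamine B assay, with a stated time of 72 h; a lower number here means a stronger inhibitor, a higher number a weaker inhibitor
- compound 1 `COc1ccc(Cn2nnc(O)c2C(=O)Nc2cccc(C(F)(F)F)c2)cc1`: 81400 nM
- compound 2 `COc1ccc(Cn2nnc(O)c2C(=O)Nc2cccc(C(F)(F)F)c2)cc1OC`: 59200 nM

Compound 1 has a single measured neighbour and stands within the scatter of it. Among the measured compounds shown here, the only measured step is a 1.4-fold lower number from compound 1 to compound 2 (0.14 log units; within the scatter), for methoxy in place of hydrogen on an aromatic carbon.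

Compound 3 `O=C(Nc1cccc(C(F)(F)F)c1)c1c(O)nnn1Cc1ccc(OC(F)(F)F)cc1` has no value yet in this assay. Its difference from compound 1 is trifluoromethyl in place of methyl on an oxygen on an aromatic ring, which is methoxy to trifluoromethoxy. For the measured compounds named here, the measured step is a different change, so it bears on this one only loosely, and no measured step shows what this replacement does. From the compounds shown here alone, with so little to go on, no step beyond the scatter is expected, and its direction remains open.

The estimated step is a 1.4-fold lower number from compound 1 to compound 3 (0.13 log units; within the scatter).

For compound 3 the expected value is 60000 nM, with an estimated range from 25000 nM to 120000 nM.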

Compound 3, half-maximal inhibitory concentration: 31300 nM
For compound 3 the middle estimate is 1.9-fold (0.28 log units) above the measured one; the range from low to high includes it.
By their numbers in this assay, from the lowest: compounds 3, 2 and 1 (each within the scatter of the next, the first and the last beyond it).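

In this assay, trifluoromethyl in place of methyl on an oxygen on an aromatic ring gives a 2.6-fold lower number from compound 1 to compound 3 (0.42 log units; beyond the scatter), so this position can respond to a change beyond the scatter, which a 1.4-fold lower number from compound 1 to compound 2 (0.14 log units; within the scatter) did not show. The step is modest, and compound 3 at 31300 nM still sits at a high number for a series read as inhibitors, so the change shifts the value without transforming it. No supporting measurement bears on why the number moves.

Open, from the compounds shown here alone, is whether the step belongs to the fluorines or would also appear with a longer chain such as ethoxy, or with an amine or a carboxylic acid in the same place. Also open, going by these compounds, is whether the same replacement gives a similar step when the rest of the structure differs from the core of compound 1.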